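Benzyl in place of 4-methoxyphenyl on an amine nitrogen

A few compounds are considered here, and "the series" means these few. Any claim that something is new, unique, unknown or untested is made for them only; others in the source may bear on it.

In a functional assay on HeLa cells (Homo sapiens) for inhibition, read by sulforhodamine B assay (a higher number here means a weaker inhibitor, a lower number a stronger inhibitor), three compounds on a shared core have been measured. Compound 1 (`O=C1C(Nc2ccccc2)=CC(=O)c2c1nc1n2[C@H]2OC[C@@H](O)[C@H]2OC1`) gives > 8000 nM as a limit of the assay, not a number. Compound 2 (`CCc1ccc(NC2=CC(=O)c3c(nc4n3[C@H]3OC[C@@H](O)[C@H]3OC4)C2=O)cc1`) gives 6510 nM as a true reading. Compound 3 (`COc1ccc(NC2=CC(=O)c3c(nc4n3[C@H]3OC[C@@H](O)[C@H]3OC4)C2=O)cc1`) gives > 8000 nM as a limit too. Compound 3 thus sits at the limit of > 8000 nM in this assay, at which 2 of the 3 values shown sit, and has no exact number.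

Compound 4 (`O=C1C(NCc2ccccc2)=CC(=O)c2c1nc1n2[C@H]2OC[C@@H](O)[C@H]2OC1`), not yet measured, has benzyl in place of 4-methoxyphenyl on an amine nitrogen as its change. The measured steps only swap groups on an aromatic carbon. Both an at least 1.2-fold lower number from compound 1 to compound 2 (0.08 log units; that floor lies within the scatter) and an at least 1.2-fold higher number from compound 2 to compound 3 (0.08 log units; that floor lies within the scatter) have floors within the scatter, while a step that the two limits leave unreadable from compound 1 to compound 3 has no readable size. None of them changes the group on the amine nitrogen, so they are only a loose guide. No step beyond the scatter is expected, in either direction, and the expected step is a number no higher from compound 3 to compound 4 (the limit leaves the size open) at its best reading. Compound 4 is estimated at 8000 nM (expected range 3000 nM to 20000 nM).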

Compound 4, half-maximal inhibitory concentration: 11000 nM
For compound 4 the middle estimate is 1.4-fold (0.14 log units) below the measured one; measured number inside the range.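

Compound 4 is the first compound shown that changes the group on the amine nitrogen itself, rather than swapping a group on an aromatic carbon, and in this assay it gives a true reading. Against the only other exact value, the change from 4-ethylphenyl to benzyl is a 1.7-fold higher number from compound 2 to compound 4 (0.23 log units; within the scatter), so this pair gives no sign that the swap at this position matters. The steps to compound 4 from compound 1 and from compound 3 cannot be read, because the values of those two compounds are limits: the limit of > 8000 nM in this assay, at which 2 of the 4 values shown sit.

Going by these compounds, whether any group on this amine nitrogen can move the number beyond the scatter stays open. A longer chain such as 2-phenylethyl, or a benzyl carrying an amine or a carboxylic acid, could test that.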